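Swapping a triazole-linked diol for a methylpiperazinylpropyl chain

The compounds below may be only part of what the source reports. "The series", "measured", "known", "first", "only" and "open" are said of these compounds alone.

Measured compounds:
compound 1 `O=C1c2c[n+]([O-])c3ccccc3c2C(=O)c2c1c1ccccc1n2Cc1cn(C[C@@H](O)CO)nn1` gives 490 nM;
compound 2 `CC1(C)OCC(Cn2cc(Cn3c4c(c5ccccc53)C(=O)c3c[n+]([O-])c5ccccc5c3C4=O)nn2)O1` gives 120 nM;
compound 3 `O=C1c2c[n+]([O-])c3ccccc3c2C(=O)c2c1c1ccccc1n2Cc1cn([C@H]2O[C@H](CO)[C@@H](O)[C@H]2O)nn1` gives 950 nM.

These three numbers come from a toxicity assay on L02 cells (Homo sapiens) for cytotoxicity, read by MTT assay, with a stated time of 72 h; a lower number here means a stronger inhibitor, a higher number a weaker inhibitor. Compound 1 stands second highest of the three: compound 3 is nearest, and the two lie within the scatter of each other, whereas compound 2 sits beyond the scatter, as the step of a 4.1-fold lower number from compound 1 to compound 2 (0.61 log units; beyond the scatter) shows. The step of a 1.9-fold higher number from compound 1 to compound 3 (0.29 log units; within the scatter) and the step of a 7.9-fold higher number from compound 2 to compound 3 (0.90 log units; beyond the scatter) complete the picture; all three measured compounds keep the same triazole-bearing side chain and differ only in what sits on the triazole.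

Compound 4 `CN1CCN(CCCCn2c3c(c4ccccc42)C(=O)c2c[n+]([O-])c4ccccc4c2C3=O)CC1` takes a different route. The change from compound 1 is 3-(4-methylpiperazin-1-yl)propyl in place of 1-(2,3-dihydroxypropyl)-1H-1,2,3-triazol-4-yl on a saturated chain carbon bound to an aromatic nitrogen. Among the measured compounds shown here, no measured step touches the triazole itself, so none of the three steps bears directly on this change; the measured steps only show that the whole set so far spans a modest range around compound 1. With nothing against it and nothing for it, compound 4 is expected to land near compound 1, a step of a 1.4-fold lower number from compound 1 to compound 4 (0.15 log units; within the scatter), with a wide range. Compound 4 is therefore estimated at 350 nM, between 80 nM and 1500 nM.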

Compound 4, half-maximal inhibitory concentration: 80 nM
Beside the measured number, compound 4's estimate is 4.4-fold (0.64 log units) above it; the measured number falls inside the stated range.
By their numbers in this assay, from the lowest: compounds 4 and 2 (each within the scatter of the next); then compounds 1 and 3 (each within the scatter of the next).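

Replacing the 1-(2,3-dihydroxypropyl)-1H-1,2,3-triazol-4-yl group with 3-(4-methylpiperazin-1-yl)propyl on a saturated chain carbon bound to an aromatic nitrogen gives, in this assay, a 6.1-fold lower number from compound 1 to compound 4 (0.79 log units; beyond the scatter). The earlier compounds shown here varied only what sits on the triazole, whereas this change shows that the number at this position can also move when the triazole and the diol are both gone. Compound 2 at 120 nM and compound 4 at 80 nM lie within the scatter of each other, so a triazole is not required to reach that level in this set.

No measurement given here accounts for the change. On these data alone, the piperazine ring and the chain enter together, so it remains open whether a morpholine ring or a longer chain at this place would give a similar number.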